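The compounds below may be only part of what the source reports. "The series", "measured", "known", "first", "only" and "open" are said of these compounds alone.

Of the compounds shown here, three have been measured in a functional assay on DU-145 cells (Homo sapiens) for inhibition, read by trypan blue exclusion, with a stated time of 72 h; a lower number here means a stronger inhibitor, a higher number a weaker inhibitor. Compound 1 `Cn1c(=O)c(S(=O)(=O)c2ccc(F)cc2[N+](=O)[O-])cc2cnc(Nc3ccc4[nH]ccc4c3)nc21` gives 1500 nM, compound 2 `Cn1c(=O)c(S(=O)(=O)Cc2ccc(F)cc2F)cc2cnc(Nc3ccc4[nH]ccc4c3)nc21` gives 1000 nM, and compound 3 `Cn1c(=O)c(S(=O)(=O)Cc2ccc(F)cc2)cc2cnc(Nc3ccc4[nH]ccc4c3)nc21` gives 30000 nM. Compound 3 therefore stands highest of the three numbers: from compound 1 the step is a 20-fold higher number from compound 1 to compound 3 (1.30 log units; beyond the scatter), and from compound 2 it is a 30-fold higher number from compound 2 to compound 3 (1.48 log units; beyond the scatter). The two lower values sit close together, a 1.5-fold lower number from compound 1 to compound 2 (0.18 log units; within the scatter).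

The next compound, compound 4 `Cn1c(=O)c(S(=O)(=O)c2ccc([N+](=O)[O-])cc2F)cc2cnc(Nc3ccc4[nH]ccc4c3)nc21`, carries 2-fluoro-4-nitrophenyl in place of 4-fluorobenzyl on a sulfonyl sulfur. The change removes the benzyl group that sets compound 3 apart and returns a nitro-bearing aryl group to the sulfonyl sulfur, as in compound 1, though as 2-fluoro-4-nitrophenyl rather than 4-fluoro-2-nitrophenyl. Among the measured compounds shown here, the one measured step that bears on it directly is the change from compound 1 to compound 3, a 20-fold higher number from compound 1 to compound 3 (1.30 log units; beyond the scatter), a large one read in reverse here. For the measured compounds named here, no measured pair shows what the different arrangement of fluoro and nitro on the aryl group does. A large fall in this assay is therefore expected for compound 4, most likely landing near the value of compound 1, with wide uncertainty from the rearranged substituents. The expected step is a 15-fold lower number from compound 3 to compound 4 (1.18 log units; beyond the scatter). Compound 4 is estimated at 2000 nM, with a range from 500 nM to 10000 nM.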

Compound 4, half-maximal inhibitory concentration: 400 nM
Beside the measured number, compound 4's estimate is 5.0-fold (0.70 log units) above it; the measured number lies below the stated range.
By their numbers in this assay, from the lowest: compound 4; then compounds 2 and 1 (each within the scatter of the next); then compound 3.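

On the sulfonyl sulfur, 2-fluoro-4-nitrophenyl gives the lowest number of the series in this assay, and compound 4 is the strongest inhibitor of the four, with each of its steps printed as beyond the scatter. The exchange for 4-fluorobenzyl is large (a 75-fold lower number from compound 3 to compound 4 (1.88 log units; beyond the scatter)), while the exchange for 2,4-difluorobenzyl is modest (a 2.5-fold lower number from compound 2 to compound 4 (0.40 log units; beyond the scatter)), so the gain over the better benzyl group is much smaller than the gain over compound 3. The pair of nitro-bearing aryl groups now shows that the arrangement of fluoro and nitro on the ring registers in this read-out, though only modestly (a 3.8-fold lower number from compound 1 to compound 4 (0.57 log units; beyond the scatter)); no evidence at hand accounts for any of these steps.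

The compounds shown leave open whether the lower number follows the nitro group, the fluoro group or the aryl group sitting directly on the sulfonyl sulfur, since a 2-fluoro-4-nitrobenzyl group and a 2,4-difluorophenyl group do not stand among them. Also open, on these data alone, is how the same ring behaves with a nitrile, an amine or a carboxylic acid where compound 4 carries its nitro group.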